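A few compounds are considered here, and "the series" means these few. Any claim that something is new, unique, unknown or untested is made for them only; others in the source may bear on it.

In a functional assay on DU-145 cells (Homo sapiens) for antiproliferative activity, read by MTT assay, with a stated time of 72 h (on this read-out lower numbers stand for stronger inhibition and higher numbers for weaker inhibition), compound 1 (`O=C(COc1ccc(C(=O)/C=C/c2cccc(Cl)c2)cc1)N[C@H]1CCOC1=O`) gives 3700 nM as the lowest of the numbers in hand. Compound 2 (`O=C(COc1ccc(C(=O)/C=C/c2ccc(Cl)cc2Cl)cc1)N[C@H]1CCOC1=O`) gives 8610 nM in the same read-out. Compound 3 (`Cc1ccc(C(C)C)c(OCCSC(=S)N[C@H]2CCOC2=O)c1`) gives > 64000 nM as a limit of the assay and not a number.

Compound 4 (`O=C(COc1ccc(C(=O)/C=C/c2ccccc2Cl)cc1)N[C@H]1CCOC1=O`) is still to be measured. The change from compound 1 is 2-chlorophenyl in place of 3-chlorophenyl on a double-bonded chain carbon bound to a double-bonded chain carbon on a double-bonded chain carbon bound to a double-bonded chain carbon, with 2-chlorophenyl in place of 3-chlorophenyl. The two have the same atoms, joined differently.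

For the measured compounds named here, the one measured step at this place is a 2.3-fold higher number from compound 1 to compound 2 (0.37 log units; beyond the scatter) and brings in 2,4-dichlorophenyl for 3-chlorophenyl. That step is modest and beyond the scatter. Going by the values given here, compound 3 offers no step to work from. Among the compounds with values here, with compound 2 as the only guide through a 2.3-fold higher number from compound 1 to compound 2 (0.37 log units; beyond the scatter) a shift of similar or smaller size toward a higher number is expected in this assay and it may stay within the scatter. The expected step is a 1.4-fold higher number from compound 1 to compound 4 (0.13 log units; within the scatter) on this estimate. For compound 4 the estimated value is 5000 nM with an expected range from 2000 nM to 12000 nM on repeat measurement.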

Compound 4, half-maximal inhibitory concentration: 3240 nM
Compound 4: the middle estimate sits 1.5-fold (0.19 log units) above what was measured; the measured number falls inside the stated range.
By their numbers in this assay, from the lowest: compounds 4 and 1 (each within the scatter of the next); then compound 2. At a limit, above all of these: compound 3.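

In this assay, 2-chlorophenyl in place of 3-chlorophenyl on a double-bonded chain carbon bound to a double-bonded chain carbon gives a 1.1-fold lower number from compound 1 to compound 4 (0.06 log units; within the scatter), so this change separates the two chlorophenyl isomers by no more than repeat measurement would. The extra chloro does register: hydrogen in place of chloro on an aromatic carbon gives a 2.7-fold lower number from compound 2 to compound 4 (0.42 log units; beyond the scatter), which places the difference of compound 2 from compound 4 on that one chloro, and the step remains modest. Nothing measured here offers a cause for either step.

Still open, going by these compounds, is whether a phenyl carrying no chloro, or one carrying an amine or a carboxylic acid, at this place stays in the range of compound 1 and compound 4. Also open, on these data alone, is whether a longer chain between the two double-bonded carbons and the ring would hold that range.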